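Cytotoxicity of Selenium Naphthoquinones: Predicting a tert-Butoxycarbonylamino to Phenylselanyl Swap

The compounds below may be only part of what the source reports. "The series", "measured", "known", "first", "only" and "open" are said of these compounds alone.

In an ADME assay on PHF cells (Homo sapiens) for cytotoxicity, read by MTT assay, with a stated time of 24 h (on this read-out lower numbers stand for stronger inhibition and higher numbers for weaker inhibition), three compounds sharing one naphthoquinone core have been measured. Compound 1 `CC1=C([Se]CC(OC(=O)[C@@H](CO)NC(=O)OC(C)(C)C)C(=O)NCCCCCC(=O)OCc2ccccc2)C(=O)c2ccccc2C1=O` gives 27000 nM, compound 2 `CC1=C(SCCC(=O)OC(C[Se]C2=C(C)C(=O)c3ccccc3C2=O)C(=O)NCCCCCC(=O)OCc2ccccc2)C(=O)c2ccccc2C1=O` gives 5000 nM, and compound 3 `CC1=C([Se]CC(OC(=O)CNC(=O)OC(C)(C)C)C(=O)NCCCCCC(=O)OCc2ccccc2)C(=O)c2ccccc2C1=O` gives 6000 nM. Compound 3 therefore holds the second highest number of the three: compound 2 sits within the scatter of it, while compound 1 stands clearly higher, as seen in the step of a 4.5-fold lower number from compound 1 to compound 3 (0.65 log units; beyond the scatter) when hydrogen replaces hydroxymethyl.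

Compound 4 `CC1=C([Se]CC(OC(=O)CC[Se]c2ccccc2)C(=O)NCCCCCC(=O)OCc2ccccc2)C(=O)c2ccccc2C1=O` arises from compound 3 by the change (a group of 8 heavy atoms (7 carbon, 1 selenium; one six-membered aromatic ring of carbon only) in place of a group of 8 heavy atoms (5 carbon, 1 nitrogen, 2 oxygen; no ring), on a saturated chain carbon bound to a carbonyl carbon). Within the data shown here, no measured step touches this position, so the only guidance is indirect: the step from compound 1 to compound 3, which trimmed a substituent nearby, lowered the number modestly, and compound 2, which carries a second selenium-bearing arm, sits close to compound 3. A small to modest decrease in the number is therefore expected, a 1.5-fold lower number from compound 3 to compound 4 (0.18 log units; within the scatter), though nothing rules out no change beyond the scatter. The estimate for compound 4 in this assay is 4000 nM, between 1500 nM and 12000 nM.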

Compound 4, half-maximal inhibitory concentration: 6000 nM
The estimate for compound 4 lay 1.5-fold (0.18 log units) below the measured number, and the stated range covers the measured number.
By their numbers in this assay, from the lowest: compounds 2, 3 and 4 (each within the scatter of the next); then compound 1.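

At this saturated chain carbon bound to a carbonyl carbon, this assay shows that a large exchange can leave the number in place: replacing (tert-butoxycarbonyl)amino, which has a hydrogen-bond donor and acceptors, with a group of equal heavy-atom count that has a six-membered aromatic ring, a selenium atom and neither donors nor acceptors gives no change at the digits printed from compound 3 to compound 4 (within the scatter). Exchanging the whole group on the carbonyl carbon of compound 1 for the selenium-bearing group of compound 4 gives a 4.5-fold lower number from compound 1 to compound 4 (0.65 log units; beyond the scatter), so this change goes with a clear drop. No measurement here offers an explanation for either result.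

As far as these compounds go, it remains open how a free amine at this carbon would read. A phenylthio group, with sulfur in place of selenium, or a longer chain carrying the phenylselanyl group, is equally untested among these compounds.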